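Replacing the (4-carboxyphenyl)amino group: working notes on compound 4

The source may report more compounds than this note shows. Statements on the series, on what has been measured and on what is new or still open speak of the compounds shown alone.

- compound 1 (`CCCc1nn(C)c2c(Nc3ccc(C(=O)O)cc3)nc(-c3cc(OC)c(OC)c(OC)c3)nc12`) gives 15800 nM
- compound 2 (`CCCc1nn(C)c2c(NCC(C)C)nc(/C=C/c3ccccc3)nc12`) gives 22100 nM
- compound 3 (`CCCc1nn(C)c2c(N3CCC(O)CC3)nc(/C=C/c3cc(OC)c(OC)c(OC)c3)nc12`) gives 13700 nM

In a functional assay on RAW264.7 cells (Mus musculus) for inhibition, read by Griess assay, with stated times of 1 h and 24 h (on this read-out higher numbers stand for weaker inhibition and lower numbers for stronger inhibition), compound 1 gives 15800 nM and sits within the scatter of both other measured compounds. Compound 4 (`CCCc1nn(C)c2c(N3CCCC3)nc(-c3cc(OC)c(OC)c(OC)c3)nc12`) carries pyrrolidin-1-yl in place of (4-carboxyphenyl)amino on an aromatic carbon. Going by the values given here, no measured pair differs in one place only, so no direct step is available. The three measured compounds carry different groups at this place and differ elsewhere too, yet compound 3 at 13700 nM and compound 2 at 22100 nM remain close to compound 1. The expected step of a 1.1-fold lower number from compound 1 to compound 4 (0.02 log units; within the scatter) is estimated to stay within the scatter. Compound 4 is expected at 15000 nM (estimated range 6000 nM to 40000 nM).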

Compound 4, half-maximal inhibitory concentration: "not active" (no number reported)
Compound 4: no number reported; no gap can be computed for the estimate.
By their numbers in this assay, from the lowest: compounds 3, 1 and 2 (each within the scatter of the next).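

Going by these compounds alone, compound 4 is reported as not active in this assay, with no number, and no step from compound 1 to compound 4 can be read. Nothing measured here bears on this result. The compounds shown leave open how far pyrrolidin-1-yl and (4-carboxyphenyl)amino differ on the shared core.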